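The source may hold more compounds than are shown below. What is called first, only, known or untested is meant among the compounds shown, and "the series" means these compounds.

Compound 1 `Fc1cc(Cl)ccc1-c1ccc(Cn2nnc3ccccc32)cn1` is the starting point. In an ADME assay on microsomes from liver (Rattus norvegicus, strain Wistar) for metabolic stability, tested at 2.5 uM (a higher number here means faster removal of the compound, a lower number slower removal), compound 1 gives 0.8 mL/min/g, and compound 2 `Fc1cc(Cl)ccc1-c1ccc(Cn2nnc3c(F)cccc32)cn1` gives 0.6 mL/min/g, so the two sit within the usual scatter of each other. Going by the values given here, the one measured step, a 1.3-fold lower number from compound 1 to compound 2 (0.12 log units; within the scatter), came from a fluoro in place of hydrogen on an aromatic carbon. Compound 3 `Fc1ccc2c(c1)nnn2Cc1ccc(-c2ccc(Cl)cc2F)nc1` differs from compound 1 by fluoro in place of hydrogen on an aromatic carbon. Because the step of a 1.3-fold lower number from compound 1 to compound 2 (0.12 log units; within the scatter) stayed within the scatter, the step of a 1.1-fold lower number from compound 1 to compound 3 (0.06 log units; within the scatter) is expected to do the same. Compound 3 is therefore estimated at 0.7 mL/min/g, in a range from 0.35 mL/min/g to 1.4 mL/min/g.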

Compound 3, intrinsic clearance in a liver preparation (reported as CLH), per the amount of preparation that the assay uses: 0.5 mL/min/g
Compound 3: middle estimate off by 1.4-fold (0.15 log units), on the high side; the measured number falls inside the stated range.
By their numbers in this assay, from the lowest: compounds 3, 2 and 1 (each within the scatter of the next).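

Fluoro in place of hydrogen on this aromatic carbon of the fused system of two rings gives a 1.6-fold lower number from compound 1 to compound 3 (0.20 log units; within the scatter) in this assay for this compound pair. With compound 2, this makes two fluoro placements on that ring, and each stays within the scatter of compound 1, so neither placement yet stands apart from the unsubstituted parent. As far as these compounds go, whether a larger group at this carbon, such as methoxy or an amine, would shift the number beyond the scatter stays open. No available evidence explains these small differences.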